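Sulfanyl Substitution at the Shared Core: Outlook for Compound 4

This account rests on a few compounds, and the source may have more. Where it says the series, first, only, none or still open, it means among the compounds named here.

Compound 1 `Cc1cc(N2CC[C@@H](C)[C@@H](N(C)c3ncnc4[nH]ccc34)C2)n2ncnc2n1` carries hydrogen at the aromatic carbon in question. In a functional assay on HGC-27 cells (Homo sapiens) for inhibition, read by MTT assay, with a stated time of 72 h (on this read-out higher numbers stand for weaker inhibition and lower numbers for stronger inhibition), compound 1 gives 11300 nM, the lowest of the three numbers in hand. Compound 2 `Cc1cc(N2CC[C@@H](C)[C@@H](N(C)c3ncnc4[nH]ccc34)C2)n2nc(SCc3ccccc3Br)nc2n1` gives 21300 nM in this assay, and compound 3 `C#CSc1nc2nc(C)cc(N3CC[C@@H](C)[C@@H](N(C)c4ncnc5[nH]ccc45)C3)n2n1` gives 35100 nM in this assay. The step of a 1.9-fold higher number from compound 1 to compound 2 (0.28 log units; within the scatter) lies within the scatter, the step of a 3.1-fold higher number from compound 1 to compound 3 (0.49 log units; beyond the scatter) lies beyond it, and the step of a 1.6-fold higher number from compound 2 to compound 3 (0.22 log units; within the scatter) lies within it.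

Compound 4 `Cc1cc(N2CC[C@@H](C)[C@@H](N(C)c3ncnc4[nH]ccc34)C2)n2nc(SCCCc3ccccc3)nc2n1` has not yet been measured in this assay. It differs from compound 1 as follows: (3-phenylpropyl)sulfanyl in place of hydrogen on an aromatic carbon. The two measured steps that bear on this change are a 1.9-fold higher number from compound 1 to compound 2 (0.28 log units; within the scatter) and a 3.1-fold higher number from compound 1 to compound 3 (0.49 log units; beyond the scatter), both of which go to a higher number when a sulfanyl group replaces hydrogen at this carbon. The step from compound 1 to compound 4 is therefore expected to be a modest rise, a 1.9-fold higher number from compound 1 to compound 4 (0.29 log units; within the scatter), because a 1.9-fold higher number from compound 1 to compound 2 (0.28 log units; within the scatter) is the closer precedent. Compound 4 is estimated at 22000 nM, with a range from 11000 nM to 45000 nM.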

Compound 4, half-maximal inhibitory concentration: > 100000 nM
Compound 4 gave a limit, no number; the forecaster's own chance of this, stated with the estimate: 10%; middle value at least 4.5-fold (0.65 log units) from the limit.
By their numbers in this assay, from the lowest: compounds 1, 2 and 3 (each within the scatter of the next, the first and the last beyond it). At a limit, above all of these: compound 4.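

In this assay compound 4 stands at a limit of the assay, not at a number: the limit of > 100000 nM in this assay, at which 1 of the 4 values shown sits. The (3-phenylpropyl)sulfanyl group in place of hydrogen on this aromatic carbon gives an at least 8.8-fold higher number from compound 1 to compound 4 (0.94 log units; beyond the scatter), so a sulfanyl change here can lie well beyond the scatter, which the step to compound 2 did not show. What sits on the sulfur also counts, with an at least 4.6-fold higher number from compound 2 to compound 4 (0.67 log units; beyond the scatter) and an at least 2.8-fold higher number from compound 3 to compound 4 (0.45 log units; beyond the scatter), whereas the earlier change on the sulfur, from compound 2 to compound 3, stayed within the scatter.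

Open, going by these compounds, is whether a methyl or ethyl group on the sulfur, or an amine or carboxylic acid at the end of the 3-phenylpropyl chain, would bring the number back down. Also open, on these data alone, is whether any replacement of hydrogen at this carbon gives a lower number than compound 1, which gives 11300 nM.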